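A Pyridinyloxy Ketone Built on an Inactive Series

A few compounds are considered here, and "the series" means these few. Any claim that something is new, unique, unknown or untested is made for them only; others in the source may bear on it.

Compound 3 has the structure `CC(C)[C@H](NC(=O)COc1cccc2ccccc12)C(=O)N[C@@H](CC(=O)O)C(=O)CSc1nc2ccccc2s1`. In a functional assay on Jurkat cells (Homo sapiens) for inhibition (on this read-out higher numbers stand for weaker inhibition and lower numbers for stronger inhibition), compound 3 gives > 200000 nM, which is a limit of the assay and not a number. Two further compounds share the same core and differ only in the group on the sulfur. Compound 1, `CC(C)[C@H](NC(=O)COc1cccc2ccccc12)C(=O)N[C@@H](CC(=O)O)C(=O)CSC1=NCCS1`, gives > 200000 nM in this assay, again a limit. Compound 2, `CC(C)[C@H](NC(=O)COc1cccc2ccccc12)C(=O)N[C@@H](CC(=O)O)C(=O)CSc1nnnn1C`, gives > 200000 nM in this assay, also a limit. The three steps among them stay unreadable because every value sits at the limit of > 200000 nM in this assay, at which 3 of the 3 values shown sit: a step that the two limits leave unreadable from compound 1 to compound 2, a step that the two limits leave unreadable from compound 1 to compound 3 and a step that the two limits leave unreadable from compound 2 to compound 3.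

Compound 4 has the structure `CC(C)[C@H](NC(=O)COc1cccc2ccccc12)C(=O)N[C@@H](CC(=O)O)C(=O)COc1ccccn1`. It differs from compound 3 by (pyridin-2-yl)oxy in place of (1,3-benzothiazol-2-yl)sulfanyl on a saturated chain carbon bound to a carbonyl carbon. This change removes the sulfur that the three measured steps kept in place, so none of those steps bears on it directly, and none of them has a readable size anyway. With every measured value at the limit, there is no basis for expecting a step of known size or direction; the step expected from compound 3 to compound 4 is a number no higher from compound 3 to compound 4 (the limit leaves the size open). For compound 4 the estimate in this assay is 200000 nM, with a range from 20000 nM to 2000000 nM, and a limit remains the most likely outcome.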

Compound 4, half-maximal inhibitory concentration: > 200000 nM
Compound 4: no number, only a limit; the forecaster's own chance of this, stated with the estimate: 70%; the middle value lies on the limit itself.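

In this assay compound 4 gives > 200000 nM, a limit of the assay and not a number. Its steps from compound 1, compound 2 and compound 3 therefore cannot be read: the limit of > 200000 nM in this assay, at which 4 of the 4 values shown sit.

The compounds shown leave open how far these four groups really differ in inhibition, and whether any group on the shared core gives a measurable value.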